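Changing the Sulfonamide Ring of a Very Potent Compound

The compounds below may be only part of what the source reports. "The series", "measured", "known", "first", "only" and "open" are said of these compounds alone.

In a functional assay on K562 cells (Homo sapiens) for inhibition, read by CCK-8 assay, with a stated time of 72 h (on this read-out lower numbers stand for stronger inhibition and higher numbers for weaker inhibition), compound 1 `O=C(/C=C/c1cccnc1)NCCCc1cccc(S(=O)(=O)Nc2ccccc2)c1` gives 86.8 nM and compound 2 `O=C(/C=C/c1cccnc1)NCCCCCCCc1cccc(S(=O)(=O)Nc2ccccc2)c1` gives 61.1 nM with no real difference between the two. Compound 3 `Cc1ccccc1NS(=O)(=O)c1cccc(CCCCCCNC(=O)/C=C/c2cccnc2)c1` stands at 0.456 nM as the lowest number of the three, well beyond the scatter from both others.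

Compound 4 `O=C(/C=C/c1cccnc1)NCCCCCCc1cccc(S(=O)(=O)Nc2ccc(F)cc2)c1` has not yet been measured. It carries 4-fluorophenyl in place of 2-methylphenyl on a sulfonamide nitrogen, a change that counts as 4-fluorophenyl in place of 2-methylphenyl on a sulfonamide nitrogen in full. Among the measured compounds shown here, its chain matches that of compound 3, so only this one group differs.

For the measured compounds named here, compound 3 at 0.456 nM is the only measured compound with 2-methylphenyl. It also differs from compound 1 and compound 2 in its chain, so the data cannot show how much of its low number belongs to that group. Losing the group may still cost some of that potency. The expected change is a 6.6-fold higher number from compound 3 to compound 4 (0.82 log units; beyond the scatter) in the direction of weaker inhibition, a step beyond the scatter. For compound 4 the estimated value is 3 nM with an expected range of 0.4 nM to 25 nM in this uncertain case.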

Compound 4, half-maximal inhibitory concentration: 0.93 nM
The estimate for compound 4 lay 3.2-fold (0.51 log units) above the measured number; the range from low to high includes it.
By their numbers in this assay, from the lowest: compound 3; then compound 4; then compounds 2 and 1 (each within the scatter of the next).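

Among the compounds shown here, with the chain held the same, this pair isolates the sulfonamide ring for the first time: in this assay, the change to 4-fluorophenyl gives a 2.0-fold higher number from compound 3 to compound 4 (0.31 log units; beyond the scatter), a modest step just beyond the usual scatter. The very low number of compound 3 therefore does not depend strictly on 2-methylphenyl, since compound 4 still reaches 0.93 nM with 4-fluorophenyl on the sulfonamide nitrogen. No measurement shown explains why the number moves.

This single swap changes both the group on the ring and its place, so the two effects cannot be separated. Going by these compounds, how plain phenyl, 4-methylphenyl or 2-fluorophenyl would compare on the chain of compound 3 remains open, as does whether a ring carrying an amine or a carboxylic acid would keep this potency.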